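Extending the Side Chain of Compound 1

The source may report more compounds than this note shows. Statements on the series, on what has been measured and on what is new or still open speak of the compounds shown alone.

Compound 1 `CCn1nc(-c2cccnc2)c2ccccc2c1=O` carries a short chain on a ring nitrogen of the shared core. In a functional assay (trachea) with Cavia porcellus as the target (on this read-out higher numbers stand for weaker inhibition and lower numbers for stronger inhibition), compound 1 gives 1320 nM, the lowest number among the three measured compounds and so the strongest inhibition seen here. Compound 2 `CCCn1nc(-c2cccnc2)c2ccccc2c1=O` gives 3160 nM in this assay, and compound 3 `O=c1c2ccccc2c(-c2cccnc2)nn1CCO` gives 4570 nM. Both differ from compound 1 at one place, on a saturated chain carbon, two bonds along the chain from an aromatic nitrogen: a 2.4-fold higher number from compound 1 to compound 2 (0.38 log units; beyond the scatter), and a 3.5-fold higher number from compound 1 to compound 3 (0.54 log units; beyond the scatter). Compound 4 `CC(C)NC(=O)CCCn1nc(-c2cccnc2)c2ccccc2c1=O` alters that same place more substantially: (isopropylcarbamoyl)methyl in place of hydrogen on a saturated chain carbon, two bonds along the chain from an aromatic nitrogen. Among the compounds with values here, both measured changes at this place weakened inhibition by modest amounts, and the group entering in compound 4 is larger than either a methyl or a hydroxy, so a weakening of similar or somewhat greater size is expected, with added uncertainty because no measured compound carries a group of this kind. The expected step is a 3.8-fold higher number from compound 1 to compound 4 (0.58 log units; beyond the scatter). Compound 4 is therefore estimated to give 5000 nM, within a range from 1800 nM to 15000 nM.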

Compound 4, half-maximal inhibitory concentration: 64600 nM
Estimate against measurement, compound 4: 13-fold (1.11 log units) below, and the stated range ends below it.
By their numbers in this assay, from the lowest: compound 1; then compounds 2 and 3 (each within the scatter of the next); then compound 4.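

The earlier changes at this place moved the number only modestly, but the full side chain gives a 49-fold higher number from compound 1 to compound 4 (1.69 log units; beyond the scatter) in this assay, so inhibition here can fall much further than compounds 2 and 3 suggested. The loss also holds against the two closer neighbours, with a 14-fold higher number from compound 3 to compound 4 (1.15 log units; beyond the scatter) when hydroxy is replaced, and a 20-fold higher number from compound 2 to compound 4 (1.31 log units; beyond the scatter) when isopropylcarbamoyl replaces hydrogen on a saturated chain carbon, three bonds along the chain from an aromatic nitrogen. Nothing available explains the size of these steps.

The compounds shown do not separate the effect of chain length from that of the amide in the entering group. A plain hexyl chain would test length alone, while a carboxylic acid or an amine at the chain end would show whether other end groups give a similar loss.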